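Swapping methoxy for cyano on the pyridine of compound 2

This account rests on a few compounds, and the source may have more. Where it says the series, first, only, none or still open, it means among the compounds named here.

Measured compounds:
- Compound 1, `CCOc1cncc(N2CC[C@@H]3CN[C@@H]3C2)c1`: 1350 nM
- Compound 2, `COc1cc(N2C[C@@H]3CCNC[C@@H]32)cnc1Br`: 1690 nM
- Compound 3, `COc1cc(N2C[C@H]3CCNC[C@H]32)cnc1Br`: 200 nM

These three compounds were tested in a functional assay on HEK293 cells for agonist activity at Neuronal acetylcholine receptor; alpha4/beta2 (Homo sapiens), read by FLIPR; on this read-out higher numbers stand for an effect only at larger amounts of compound and lower numbers for an effect already at smaller amounts. Compound 2 has the highest number of the three; its gap to compound 1 is within the scatter, so the two cannot be ranked, while compound 3 sits clearly apart, with an 8.5-fold lower number from compound 2 to compound 3 (0.93 log units; beyond the scatter). That step rests on (the fact that compounds 2 and 3 differ only in the configuration as drawn), the two being mirror images.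

Compound 4, `N#Cc1cc(N2C[C@@H]3CCNC[C@@H]32)cnc1Br`, is not yet measured. Its change from compound 2 is cyano in place of methoxy on an aromatic carbon. Among the compounds with values here, no measured step speaks to this swap: the only step on record, from compound 2 to compound 3, changes the configuration alone and leaves every group in place, so it gives no guide to what the cyano group does. With nothing to lean on, the expected step is none beyond the scatter, which means compound 4 is estimated to land near compound 2 with an expected shift of a 1.2-fold lower number from compound 2 to compound 4 (0.08 log units; within the scatter). Compound 4 is therefore expected at 1400 nM, within a range from 350 nM to 5600 nM, the width reflecting how little the three measured compounds say about a change of this kind.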

Compound 4, half-maximal effective concentration: 109 nM
The estimate for compound 4 lay 13-fold (1.11 log units) above the measured number; the whole stated range lies above it.
By their numbers in this assay, from the lowest: compounds 4 and 3 (each within the scatter of the next); then compounds 1 and 2 (each within the scatter of the next).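

Replacing methoxy with cyano on the aromatic carbon ortho to the bromo group gives a 16-fold lower number from compound 2 to compound 4 (1.19 log units; beyond the scatter) in this assay, so the activity of this series responds strongly to the group at this position, even though both groups have the same count of heavy atoms and hydrogen-bond acceptors. Within the data shown here, the only earlier step, an 8.5-fold lower number from compound 2 to compound 3 (0.93 log units; beyond the scatter), came from inverting the stereocentres with every group left in place, whereas this result shows that changing a single group, with the configuration of compound 2 kept, can also shift the number well beyond the scatter. Nothing on record explains why this swap has such a large effect.

The compounds shown leave open whether this shift is particular to cyano or would also appear with another group at the same position, such as an amine or a carboxylic acid. They also leave open whether the same swap would have a similar effect on compound 3, which has the opposite configuration.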